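Halogen swap on the benzylic ester: chloro to fluoro

The source may report more compounds than this note shows. Statements on the series, on what has been measured and on what is new or still open speak of the compounds shown alone.

For the measured compounds named here, compound 2 (`O=C(OCc1cccc(Cl)c1)c1cccc(=O)[nH]1`) is the anchor of this small series: in an assay on isolated protein for inhibition of matrix metalloproteinase-9 (Homo sapiens) (on this read-out lower numbers stand for stronger inhibition and higher numbers for weaker inhibition), compound 2 gives 67000 nM, the only outright number among the two values shown. Compound 1 (`O=C(OCc1cccc(Oc2ccccc2)c1)c1cccc(=O)[nH]1`) is recorded in this assay only as a limit of the assay, > 150 nM. The step that the limit leaves unreadable from compound 1 to compound 2 therefore cannot be sized because of the limit of > 150 nM in this assay, at which 1 of the 2 values shown sits. Compound 3 (`O=C(OCc1cccc(F)c1)c1cccc(=O)[nH]1`) differs from compound 2 by fluoro in place of chloro on an aromatic carbon. No measured step in this series touches a halogen-for-halogen exchange, and the single recorded step is unreadable, so nothing shown argues for a change in this assay beyond the usual scatter, in either direction. The expected step is a 1.2-fold higher number from compound 2 to compound 3 (0.08 log units; within the scatter). Compound 3 is thus expected near 80000 nM in this assay, with a range from 25000 nM to 250000 nM.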

Compound 3, half-maximal inhibitory concentration: 50000 nM
Compound 3: middle estimate off by 1.6-fold (0.20 log units), on the high side; the range from low to high includes it.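

In this assay, for the compounds shown here, fluoro in place of chloro on an aromatic carbon gives the only readable step: a 1.3-fold lower number from compound 2 to compound 3 (0.13 log units; within the scatter). This position, meta to a large group, therefore accepts either halogen with no difference beyond the usual scatter, so this exchange does not separate compound 2 and compound 3 on this read-out. The steps from compound 1 to these two halogen compounds cannot be read: the limit of > 150 nM in this assay, at which 1 of the 3 values shown sits.

Going by these compounds, how the phenoxy group of compound 1 truly compares with either halogen stays open, as does whether any group at this position moves the read-out beyond the scatter. An amine, a carboxylic acid or a methoxy group at the same place would test that in this assay, and the shared core remains unexplored in the compounds shown.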